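A few compounds are considered here, and "the series" means these few. Any claim that something is new, unique, unknown or untested is made for them only; others in the source may bear on it.

Compound 1, `Cc1cn([C@@H]2O[C@H](CO[Si](C)(C)C(C)(C)C)[C@@]3(OS(=O)(=O)C=C3NCC(=O)O)[C@H]2O[Si](C)(C)C(C)(C)C)c(=O)n(C)c1=O`, and compound 2, `Cc1cn([C@@H]2O[C@H](CO[Si](C)(C)C(C)(C)C)[C@@]3(OS(=O)(=O)C=C3NCCC(N)=O)[C@H]2O[Si](C)(C)C(C)(C)C)c(=O)n(C)c1=O`, share a core and differ in one place. In a functional assay on HEL cells (Homo sapiens) for cytotoxicity, read by microscopy (a lower number here means that less compound is tolerated, a higher number that more compound is tolerated), compound 1 gives 300000 nM. For compound 2 this assay reports only a limit, >= 80000 nM, and not a number. Going by the values given here, the step from one to the other, a step that the limit leaves unreadable from compound 1 to compound 2, therefore cannot be read, and the only evidence on the measured step is the limit of >= 80000 nM in this assay, at which 1 of the 2 values shown sits. Compound 3, `COC(=O)CCNC1=CS(=O)(=O)O[C@@]12[C@@H](CO[Si](C)(C)C(C)(C)C)O[C@@H](n1cc(C)c(=O)n(C)c1=O)[C@@H]2O[Si](C)(C)C(C)(C)C`, differs from compound 2 by methoxy in place of amino on a carbonyl carbon. No measured step addresses this change, so the expectation for compound 3 rests on the two values already shown, neither of which lies low, and on the fact that the limit leaves the step between compounds 1 and 2 unreadable. Compound 3 is therefore expected to give about 200000 nM in this assay, within 80000 nM to 500000 nM, a change from compound 2 of a step that the limit leaves unreadable from compound 2 to compound 3 that is an estimate rather than a reading.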

Compound 3, minimum cytotoxic concentration: >= 400000 nM
Compound 3: only a limit was reported (the forecaster's own chance of this, stated with the estimate: 50%); middle value at least 2.0-fold (0.30 log units) away from the limit.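

Compound 3, with methoxy in place of amino on a carbonyl carbon, again gives only a limit in this assay, >= 400000 nM, and not a number. Going by these compounds alone, the one step that can be read is an at least 1.3-fold higher number from compound 1 to compound 3 (0.12 log units; that floor lies within the scatter), so (methoxycarbonyl)methyl in place of carboxy brings no sign of a lower number in this assay, although the floor of this step does not go beyond the scatter. The other steps among these compounds cannot be read, so the change from amino to methoxy has no measured size here.

Where compound 2 and compound 3 would fall as actual numbers stays open. So does whether a primary amine or a longer chain ending in an ethyl ester at this place would give a lower number in this assay.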